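The source may report more compounds than this note shows. Statements on the series, on what has been measured and on what is new or still open speak of the compounds shown alone.

Working notes on the series. Compound 1 `COc1ccc(Cc2coc3cc(O)cc(O)c3c2=O)cc1` and compound 2 `COc1ccccc1Cc1coc2cc(O)cc(O)c2c1=O` hold the same atoms joined differently; the difference between the two cores is not broken down here. Compound 3 `COc1ccccc1Cc1coc2cc(O)ccc2c1=O` and compound 4 `COc1ccc(Cc2coc3cccc(O)c3c2=O)cc1` each carry one hydroxy fewer than their parent. In a functional assay on H9c2 cells (Mus musculus) for cytotoxicity against H9c2 (Rattus norvegicus), read by MTT assay, with a stated time of 24 h (on this read-out lower numbers stand for an effect already at smaller amounts and higher numbers for an effect only at larger amounts of compound), compound 2 gives 24400 nM. Compound 3 gives 12700 nM in this assay. For compound 1 the reading in this assay is only a limit, > 100000 nM, as the limit of > 100000 nM in this assay, at which 1 of the 3 values shown sits, shows. The change from compound 2 to compound 3, (hydrogen in place of hydroxy on an aromatic carbon), made a 1.9-fold lower number from compound 2 to compound 3 (0.28 log units; within the scatter). The change from compound 1 to compound 4, (hydrogen in place of hydroxy on an aromatic carbon), is the same kind of change, but the surroundings differ: the site in the first is ortho to a fused ring, in the second para to a fused ring. Because compound 1 sits at the limit of > 100000 nM in this assay, at which 1 of the 3 values shown sits, and the earlier step of a 1.9-fold lower number from compound 2 to compound 3 (0.28 log units; within the scatter) stays within the scatter, compound 4 is expected to give 100000 nM in this assay, a step of a number no higher from compound 1 to compound 4 (the limit leaves the size open), quite possibly reported as a limit again.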

Compound 4, half-maximal effective concentration: > 100000 nM
Compound 4: only a limit was reported (the forecaster's own chance of this, stated with the estimate: 60%); the middle value lies on the limit itself.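

Compound 1 and compound 4 are both reported only as limits in this assay, so no step between them can be read: the limit of > 100000 nM in this assay, at which 2 of the 4 values shown sit.

The compounds shown leave open whether hydrogen in place of hydroxy changes the reading on the core of compound 1.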